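The compounds below may be only part of what the source reports. "The series", "measured", "known", "first", "only" and "open" are said of these compounds alone.

Measured so far in a functional assay on KB cells (Homo sapiens) for antiproliferative activity, read by sulforhodamine B assay, with a stated time of 3 days; on this read-out higher numbers stand for weaker inhibition of growth and lower numbers for stronger inhibition of growth:
- Compound 1 `COc1ccc(N2CCN(C)CC2)cc1Nc1ncc(F)c(Nc2ccc(F)cc2)n1`: 960 nM
- Compound 2 `O=C(Nc1nccs1)c1cccc(Nc2ncc(F)c(Nc3ccc(F)cc3)n2)c1`: > 10000 nM (a limit)
- Compound 3 `O=C(Nc1ccc(C(F)(F)F)cc1)c1cccc(Nc2ncc(F)c(Nc3ccc(F)cc3)n2)c1`: > 10000 nM (a limit)

Compound 2 has no number of its own, only the limit > 10000 nM. Its place in the set is given by the limit of > 10000 nM in this assay, at which 2 of the 3 values shown sit. Compound 4 `O=C(Nc1cccc(Nc2ncc(F)c(Nc3ccc(F)cc3)n2)c1)c1cnccn1` is still unmeasured. It differs from compound 2 as follows: ((pyrazin-2-yl)carbonyl)amino in place of (1,3-thiazol-2-yl)carbamoyl on an aromatic carbon.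

Among the compounds with values here, the one measured step that touches this part of compound 2 is a step that the two limits leave unreadable from compound 2 to compound 3. Its size cannot be read, and neither end of it gives a number. Compound 3 also has only a limit, > 10000 nM. Within the data shown here, compound 1 is the only compound with a number, 960 nM, and it has no carbonyl group. With no readable step to go on, no clear change is expected in this assay, and compound 4 is expected to stay near the limit. The expected step is a step that the limit leaves unreadable from compound 2 to compound 4, and its direction cannot be fixed from limits alone. For compound 4 the estimated value is 12000 nM. The expected range for compound 4 runs from 4000 nM to 40000 nM.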

Compound 4, concentration for 50% growth inhibition: 23600 nM
Beside the measured number, compound 4's estimate is 2.0-fold (0.29 log units) below it; low and high end bracket the measured number.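

In this assay no new step can be read between compound 4 and compound 2: compound 2 has only a limit, > 10000 nM. The compounds shown leave open whether ((pyrazin-2-yl)carbonyl)amino in place of (1,3-thiazol-2-yl)carbamoyl changes growth inhibition at all, and in which direction.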